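The source may report more compounds than this note shows. Statements on the series, on what has been measured and on what is new or still open speak of the compounds shown alone.

Measured so far in an ADME assay on Detroit 551 cells (Homo sapiens) for cytotoxicity, read by MTT assay, with a stated time of 48 h; a higher number here means a weaker inhibitor, a lower number a stronger inhibitor:
compound 1 `COc1ccc2[nH]c(-c3ccc[se]3)cc(=O)c2c1OC` gives > 100000 nM
compound 2 `COc1ccc2[nH]c(-c3ccc[se]3)cc(=O)c2c1O` gives 100000 nM
compound 3 `COc1ccc2[nH]c(-c3ccc(C)[se]3)cc(=O)c2c1OC` gives > 50000 nM

The value of compound 1 in this assay is a limit of the assay, not a number. The value of compound 3 is likewise only a limit. Compound 3 therefore cannot be ranked against the other two; all three sit at the weak end of what this assay reads, and compound 2 alone gives a number.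

Compound 4 `COc1ccc2[nH]c(-c3ccc(C)[se]3)cc(=O)c2c1O` differs from compound 3 by hydrogen in place of methyl on an oxygen on an aromatic ring — the same difference, cut one bond further out, reads methoxy to hydroxy. The closest measured precedent is a number no higher from compound 1 to compound 2 (the limit leaves the size open), the identical change on the shared core lacking the methyl on the aromatic carbon; its size is open. The other step, a step that the two limits leave unreadable from compound 1 to compound 3, is unreadable because the limit of > 100000 nM in this assay, at which 1 of the 3 values shown sits, and the limit of > 50000 nM in this assay, at which 1 of the 3 values shown sits, bound both ends.

On that basis compound 4 is expected to remain a weak inhibitor, near 100000 nM, with a range of 40000 nM to 250000 nM. This corresponds to an expected step that the limit leaves unreadable from compound 3 to compound 4, nothing beyond the scatter, and a further limit-only result would not surprise.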

Compound 4, half-maximal inhibitory concentration: > 50000 nM
Compound 4 gave a limit, no number; the forecaster's own chance of this, stated with the estimate: 60%; the middle value is on the limit's open side.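

No new step can be read from compound 2 or compound 3 to compound 4. In this assay compound 4 gives > 50000 nM, a limit and not a number. The compounds shown leave open whether methoxy to hydroxy, or methyl in place of hydrogen on an aromatic carbon, shifts the reading in this assay at all.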